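Amide tail change on the hydroxy analogue

A few compounds are considered here, and "the series" means these few. Any claim that something is new, unique, unknown or untested is made for them only; others in the source may bear on it.

Of the compounds shown here, three of a shared core have been measured in an assay on HL-60 cells for agonist activity at vitamin D3 receptor (Homo sapiens), read by microscopy, with a stated time of 96 h; on this read-out lower numbers stand for an effect already at smaller amounts and higher numbers for an effect only at larger amounts of compound. Compound 1 `CCOC(=O)CN(C)C(=O)c1ccc(C(CC)(CC)c2ccc(OCC(=O)C(C)(C)C)c(C)c2)n1CC` gives only a limit, > 50000 nM, a value that is an assay limit and not a number (the limit of > 50000 nM in this assay, at which 1 of the 3 values shown sits). Compound 2 `CCn1c(C(=O)NCCN)ccc1C(CC)(CC)c1ccc(OCC(=O)C(C)(C)C)c(C)c1` gives 120 nM, so that the change of (2-aminoethyl)amino in place of ((ethoxycarbonyl)methyl)(methyl)amino on a carbonyl carbon is read as an at least 410-fold lower number from compound 1 to compound 2 (2.61 log units; beyond the scatter). Compound 3 `CCn1c(C(=O)NCCN)ccc1C(CC)(CC)c1ccc(OCC(O)C(C)(C)C)c(C)c1` gives 10 nM, the lowest number shown, with the step of a 12-fold lower number from compound 2 to compound 3 (1.08 log units; beyond the scatter) separating it from compound 2.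

Compound 4 `CCn1c(C(=O)N(C)CC(=O)O)ccc1C(CC)(CC)c1ccc(OCC(O)C(C)(C)C)c(C)c1` has not yet been measured. It differs from compound 3 in one place: (carboxymethyl)(methyl)amino in place of (2-aminoethyl)amino on a carbonyl carbon. This change runs in the opposite sense to the one seen in the move an at least 410-fold lower number from compound 1 to compound 2 (2.61 log units; beyond the scatter), although there the entering group carried an ester where compound 4 carries an acid, and the hydroxyl of compound 3 is kept. A large rise in the number is therefore expected, with the step from compound 3 to compound 4 estimated as a 200-fold higher number from compound 3 to compound 4 (2.30 log units; beyond the scatter). Compound 4 is expected to give about 2000 nM in this assay, within a range of 200 nM to 30000 nM.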

Compound 4, half-maximal effective concentration: 740 nM
Beside the measured number, compound 4's estimate is 2.7-fold (0.43 log units) above it, and the stated range covers the measured number.
By their numbers in this assay, from the lowest: compound 3; then compound 2; then compound 4. At a limit, above all of these: compound 1.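

In this assay, the amide tail still matters once the 1-hydroxy-2,2-dimethylpropyl group is in place: replacing (2-aminoethyl)amino with (carboxymethyl)(methyl)amino on the carbonyl carbon gives a 74-fold higher number from compound 3 to compound 4 (1.87 log units; beyond the scatter). Among these compounds, the earlier tail step, an at least 410-fold lower number from compound 1 to compound 2 (2.61 log units; beyond the scatter), was seen only with the (tert-butyl)carbonyl group, so this result shows that the position is also sensitive with the hydroxyl present, while compound 4 still gives a measured number rather than a limit. Nothing measured here bears on why the change has this effect.

The compounds shown leave open which part of the entering group carries the step, the carboxylic acid or the methyl on the amide nitrogen. They also leave open how an ethyl ester, a longer amine chain or a longer carboxylic acid chain would read with the hydroxyl in place.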